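Series notes: phenoxy in place of methylamino at the chain carbon

This account rests on a few compounds, and the source may have more. Where it says the series, first, only, none or still open, it means among the compounds named here.

Compound 3 `CC(c1ccc(OCc2c(-c3c(Cl)cccc3Cl)noc2C2CC2)nc1C(F)(F)F)N(C)c1ccc(C(=O)O)cc1` gives 57% in a functional assay on HEK293 cells for agonist activity at Bile acid receptor (Homo sapiens), read by a luciferase reporter; on this read-out higher numbers stand for larger maximal responses and lower numbers for smaller maximal responses. Compound 1 `CN(Cc1ccc(C(=O)NCCS(=O)(=O)O)cc1)c1ccc(OCc2c(-c3c(Cl)cccc3Cl)noc2C2CC2)nc1C(F)(F)F` gives 49% in this assay, and compound 2 `CC(Nc1ccc(C(=O)O)cc1)c1ccc(OCc2c(-c3c(Cl)cccc3Cl)noc2C2CC2)nc1C(F)(F)F` gives 49% in this assay; all three numbers lie within the scatter of one another, so no order among them can be read. Compound 4 `CC(Oc1ccc(C(=O)O)cc1)c1ccc(OCc2c(-c3c(Cl)cccc3Cl)noc2C2CC2)nc1C(F)(F)F` differs from compound 3 as follows: 4-carboxyphenoxy in place of (4-carboxyphenyl)(methyl)amino on a saturated chain carbon bound to an aromatic carbon and a saturated chain carbon. Among the compounds with values here, only one measured step touches this part of the molecule, a number 8 percentage points higher from compound 2 to compound 3 (within the scatter), and it stayed within the scatter; it concerns methyl in place of hydrogen on a nitrogen, not the exchange of that nitrogen for oxygen, so the present change is not directly covered. In this assay compound 4 is expected to give 50%, with a range from 30% to 70%. The expected step is a number 7 percentage points lower from compound 3 to compound 4 (within the scatter), nothing beyond the scatter.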

Compound 4, largest response reached (reported as efficacy), in percent of the reference or control that the assay uses: 33%
Compound 4: middle estimate off by 17 percentage points, on the high side, and the stated range covers the measured number.
By their numbers in this assay, from the lowest: compound 4; then compounds 1, 2 and 3 (each within the scatter of the next).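

Nitrogen at this link cannot be exchanged for oxygen without cost in this assay: the 4-carboxyphenoxy group falls below the (4-carboxyphenyl)(methyl)amino group (a number 24 percentage points lower from compound 3 to compound 4 (beyond the scatter)) and below the (4-carboxyphenyl)amino group (a number 16 percentage points lower from compound 2 to compound 4 (beyond the scatter)). Within the data shown here, the methyl on nitrogen gave only a step within the scatter (a number 8 percentage points higher from compound 2 to compound 3 (within the scatter)), so the exchange of nitrogen for oxygen is the first change at this position to move the response beyond it. Nothing measured here accounts for the loss.

As far as these compounds go, whether a sulfur atom or a methylene group at this link would behave like the nitrogen or like the oxygen remains open. So does the effect of replacing the carboxylic acid of compound 4 with a sulfonic acid amide of the kind carried by compound 1.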